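The compounds below may be only part of what the source reports. "The series", "measured", "known", "first", "only" and "open" are said of these compounds alone.

Compound 1 `COc1ccc(S(=O)(=O)Nc2cccc3cc(Cl)[nH]c23)cc1`: 0.17 ug/mL
Compound 2 `COc1ccc(S(=O)(=O)Nc2cccc3c(Cl)c[nH]c23)cc1`: 0.2 ug/mL

In a functional assay on MC-38 cells (Mus musculus) for antiproliferative activity, read by colorimetric assay and MTT assay (on this read-out lower numbers stand for stronger inhibition and higher numbers for weaker inhibition), compound 1 stands level with compound 2, as their two numbers lie within the usual scatter of each other. Compound 3 `O=S(=O)(Nc1cccc2cc(Cl)[nH]c12)c1ccc(Cl)cc1` keeps the core of compound 1 but carries chloro in place of methoxy on an aromatic carbon, para to a large group (chloro in place of methoxy on an aromatic carbon). Among the compounds with values here, no measured pair here shows what this swap does. The expected step, a 1.8-fold higher number from compound 1 to compound 3 (0.25 log units; within the scatter), is a slight weakening that stays within the scatter. For compound 3 the estimated value is 0.3 ug/mL, with an expected range of 0.1 ug/mL to 0.9 ug/mL.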

Compound 3, half-maximal inhibitory concentration: 10 ug/mL
The estimate for compound 3 lay 33-fold (1.52 log units) below the measured number; the measured number lies above the stated range.
By their numbers in this assay, from the lowest: compounds 1 and 2 (each within the scatter of the next); then compound 3.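

In this assay, putting chloro in place of methoxy on this aromatic carbon, para to a large group, brings a large weakening (a 59-fold higher number from compound 1 to compound 3 (1.77 log units; beyond the scatter)). This carbon is therefore far from indifferent to what it carries, something compound 1 and compound 2 could not show, as both hold methoxy there. Nothing available explains the loss.

On these data alone, whether an amine or a hydroxyl on this carbon would stay level with compound 1 or fall like compound 3 remains open. So does whether the same swap would cost as much on the core of compound 2.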